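The source may hold more compounds than are shown below. What is called first, only, known or untested is meant among the compounds shown, and "the series" means these compounds.

Of the compounds shown here, two sharing one core have been tested in a functional assay on DU-145 cells (Homo sapiens) for cytotoxicity, read by CCK-8 assay; a lower number here means a stronger inhibitor, a higher number a weaker inhibitor. Compound 1 `Oc1ccc(-c2cc(-c3ccoc3)cc(-c3ccccc3O)n2)cc1` gives 28000 nM. Within the data shown here, compound 2 `Oc1ccc(-c2cc(-c3ccoc3)cc(-c3cccc(O)c3)n2)cc1` gives 2700 nM, which is the lower of the two numbers measured so far. Among the measured compounds shown here, the only measured step is a 10-fold lower number from compound 1 to compound 2 (1.02 log units; beyond the scatter), a large gain that came from shifting the hydroxyl group on one of the phenyl rings.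

Compound 3 `Oc1ccc(-c2cc(-c3ccoc3)cc(-c3ccc(O)cc3)n2)cc1` has not yet been measured. It differs from compound 2 in a single place: 4-hydroxyphenyl in place of 3-hydroxyphenyl on an aromatic carbon. For the measured compounds named here, the one measured step bears on this change in the sense that it also moved a hydroxyl group on the same phenyl ring, and it was large. Whether a further shift of that hydroxyl continues in the same direction, reverses, or makes no difference is not shown by any measured pair, so a modest step is expected, a 1.4-fold lower number from compound 2 to compound 3 (0.13 log units; within the scatter), with wide room on either side. For compound 3 the estimate in this assay is 2000 nM, within a range from 500 nM to 10000 nM.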

Compound 3, half-maximal inhibitory concentration: 3440 nM
Beside the measured number, compound 3's estimate is 1.7-fold (0.24 log units) below it; low and high end bracket the measured number.
By their numbers in this assay, from the lowest: compounds 2 and 3 (each within the scatter of the next); then compound 1.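

In this assay, putting 4-hydroxyphenyl in place of 3-hydroxyphenyl gives a 1.3-fold higher number from compound 2 to compound 3 (0.11 log units; within the scatter) and so makes no readable difference at this position, an aromatic carbon next to the ring nitrogen. Starting instead from the 2-hydroxyphenyl group, the same 4-hydroxyphenyl group gives an 8.1-fold lower number from compound 1 to compound 3 (0.91 log units; beyond the scatter) and thus shows that the earlier gain is not unique to 3-hydroxyphenyl: among these three compounds, compound 1 alone stands apart, while compound 2 and compound 3 cannot be told apart. Nothing available explains why the 2-hydroxyphenyl group differs from the other two.

The compounds shown leave open whether the hydroxyl on this ring is needed at all, a question that a plain phenyl ring, or a methoxy group or an amine in the hydroxyl's place, could answer. They also leave open whether the same pattern would hold if the hydroxyl moved on the other 4-hydroxyphenyl group, or whether the furan-3-yl group contributes to these numbers.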